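This account rests on a few compounds, and the source may have more. Where it says the series, first, only, none or still open, it means among the compounds named here.

Compound 1 `CCCCCC(=O)Nc1cc2nc(C3CCCCC3)[nH]c2cc1N(CC)CC` gives "not determined" (no result reported) in an ADME assay on Vero cells (Chlorocebus sabaeus) for cytotoxicity, read by resazurin assay, with a stated time of 3 days; a lower number here means a stronger inhibitor, a higher number a weaker inhibitor. Compound 2 `CCCC(C)OC(=O)Nc1cc2nc(C3CCCCC3)[nH]c2cc1N(CC)CC` gives > 100 ug/mL, which is a limit of this assay and not a number. Compound 3 `CCN(CC)c1cc2[nH]c(C3CCCCC3)nc2cc1NC(=O)c1ccc(C)cc1` gives > 100 ug/mL, likewise only a limit.

Compound 3 thus stands at the limit, with one other limit and one entry without a number beside it. Compound 4 `CCN(CC)c1cc2[nH]c(C3CCCCC3)nc2cc1NC(=O)OCCOCCOC` differs from compound 3 by 2-(2-methoxyethoxy)ethoxy in place of 4-methylphenyl on a carbonyl carbon. Going by the values given here, the one step on the same carbonyl carbon, a step that the two limits leave unreadable from compound 2 to compound 3, has no readable size; what is known is the limit of > 100 ug/mL in this assay, at which 2 of the 3 values shown sit, so no step beyond the scatter is foreseen in this assay. Compound 4 is therefore expected to give 150 ug/mL, in a range from 60 ug/mL to 400 ug/mL, an expected step that the limit leaves unreadable from compound 3 to compound 4.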

Compound 4, half-maximal inhibitory concentration: > 100 ug/mL
Compound 4 ended at the assay's limit; the forecaster's own chance of this, stated with the estimate: 85%; the middle value does not contradict the limit.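

No new step can be read among compound 2, compound 3 and compound 4, since each value is only a limit: the limit of > 100 ug/mL in this assay, at which 3 of the 4 values shown sit.

The compounds shown leave open whether the groups on the carbonyl carbon change the result in this assay at all.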